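The compounds below may be only part of what the source reports. "The series", "measured", "known", "first", "only" and "open" are said of these compounds alone.

Values measured so far in a functional assay on T47D cells (Homo sapiens) for antiproliferative activity, read by MTT assay, with a stated time of 24 h; a higher number here means a weaker inhibitor, a lower number a stronger inhibitor

compound 1 `O=S(=O)(Nc1ccc2cc[nH]c2c1)c1ccc(F)cc1` gives 33000 nM
compound 2 `N#Cc1ccc(C(=O)Nc2ccc3cc[nH]c3c2)cc1` gives 35800 nM
compound 3 `O=C(Nc1ccc2cc[nH]c2c1)c1ccc(C(F)(F)F)cc1` gives 51300 nM

The gaps from compound 1 to compound 2 and to compound 3 both lie within the scatter, so these three compounds sit at one level and compound 1 cannot be separated from either of the others.

Compound 4 `COc1ccc(S(=O)(=O)Nc2ccc3cc[nH]c3c2)cc1` has not yet been measured. Its difference from compound 1 is methoxy in place of fluoro on an aromatic carbon with methoxy in place of fluoro on an aromatic carbon, para to a large group. Within the data shown here, no measured step removes fluoro or brings in methoxy. Among the measured compounds shown here, the only measured step at such a carbon is a 1.4-fold higher number from compound 2 to compound 3 (0.16 log units; within the scatter) with trifluoromethyl in place of cyano, and the link to the shared core in those two compounds differs from that of compound 1. This is indirect evidence, and it shows a step that stays within the scatter. No step beyond the scatter is therefore expected in this assay and no direction can be called. The estimated change is a 1.1-fold higher number from compound 1 to compound 4 (0.03 log units; within the scatter) and is expected to remain within the scatter. For compound 4 the expected value is 35000 nM with 15000 nM to 75000 nM as the estimated range.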

Compound 4, half-maximal inhibitory concentration: 45000 nM
For compound 4 the middle estimate is 1.3-fold (0.11 log units) below the measured one; low and high end bracket the measured number.
By their numbers in this assay, from the lowest: compounds 1, 2, 4 and 3 (each within the scatter of the next).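

In this assay, among these compounds, methoxy in place of fluoro on the aromatic carbon para to a large group gives a 1.4-fold higher number from compound 1 to compound 4 (0.13 log units; within the scatter) and so stays within the scatter, which is the first direct reading of a change at this carbon with the link of compound 1. The earlier reading at such a carbon, a 1.4-fold higher number from compound 2 to compound 3 (0.16 log units; within the scatter), came from compounds with a different link and a different pair of groups; both steps now lie within the scatter, so at this carbon neither link has yet shown a change that can be separated from repeat noise. With four compounds at one level in this assay, the series offers no direction for this exchange, and no measurement at hand accounts for the size of the step.

On these data alone, whether an amine or a carboxylic acid on this carbon, or a longer chain such as butoxy in place of methoxy, would give a step beyond the scatter remains open. Also open, as far as these compounds go, is whether methoxy in place of fluoro gives a similar step on compounds with the link of compound 2, where the carbon so far carries only cyano or trifluoromethyl.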